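The source may hold more compounds than are shown below. What is called first, only, known or untested is meant among the compounds shown, and "the series" means these compounds.

Measured so far:
compound 1, `O=C(Nc1cccc(-n2cc(-c3ccncc3)c(-c3ccc(Cl)c(O)c3)n2)c1)Nc1cccc(C(F)(F)F)c1`, > 32500 nM
compound 2, `COc1cc(-c2nn(-c3cccc(NC(=O)Nc4cccc(C(F)(F)F)c4)c3)cc2-c2ccncc2)ccc1Cl`, > 50000 nM

In a functional assay on T47D cells (Homo sapiens) for inhibition, read by sulforhodamine B assay, with a stated time of 48 h (a higher number here means a weaker inhibitor of growth, a lower number a stronger inhibitor of growth), compound 1 gives > 32500 nM, which is a limit of the assay and not a number. Compound 2 gives > 50000 nM in the same assay, again a limit rather than a number. Among the measured compounds shown here, the only step between measured compounds, a step that the two limits leave unreadable from compound 1 to compound 2, cannot be sized because the limit of > 32500 nM in this assay, at which 1 of the 2 values shown sits, and the limit of > 50000 nM in this assay, at which 1 of the 2 values shown sits, are both limits, so neither its direction nor its size is known. Compound 1 therefore stands only at a limit, with nothing measured that places it more closely.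

Compound 3, `O=C(Nc1cccc(-n2cc(-c3ccncc3)c(-c3ccc(Cl)c(O)c3)n2)c1)Nc1ccc(Cl)c(C(F)(F)F)c1`, differs from compound 1 by chloro in place of hydrogen on an aromatic carbon. No measured step touches this change: the one step shown concerns a methyl in place of hydrogen on an oxygen on an aromatic ring and is itself unreadable. Nothing measured gives ground to expect compound 3 to move off the limit where compound 1 sits, so the expectation rests on compound 1 alone. Compound 3 is expected to give about 40000 nM, within 10000 nM to 120000 nM. The expected step from compound 1 is a step that the limit leaves unreadable from compound 1 to compound 3, most likely not readable beyond the scatter.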

Compound 3, concentration for total growth inhibition: > 32500 nM
Compound 3 gave a limit, no number (the forecaster's own chance of this, stated with the estimate: 75%); the middle value is on the limit's open side.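

Among the compounds shown here, compound 3, like compound 1, gives only a limit of the assay and not a number, so no step from compound 1 to compound 3 can be read. The compounds shown leave open whether chloro in place of hydrogen on an aromatic carbon changes growth inhibition at all, and where any of the three compounds would fall beyond its limit.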